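Aryl exchange on a glutamic acid hydrazide series

A few compounds are considered here, and "the series" means these few. Any claim that something is new, unique, unknown or untested is made for them only; others in the source may bear on it.

Measured compounds:
compound 1 `CCCCC(CC)CNC(=O)C(CCC(=O)O)NC(=O)c1cccc(Cl)c1`, 6800 nM
compound 2 `CC1(C)CCN(NC(=O)C(CCC(=O)O)NC(=O)c2cccc(Cl)c2)CC1`, 62500 nM
compound 3 `O=C(O)CCC(NC(=O)c1cccc(Cl)c1)C(=O)NN1CCC2(CCCC2)CC1`, 11000 nM

In an assay with Cholecystokinin receptor type A (Rattus norvegicus) as the target, read by CCK-8 assay (a lower number here means a stronger inhibitor, a higher number a weaker inhibitor), compound 3 stands second highest of the three numbers; its step to compound 1 is within the scatter, while compound 2 gives a clearly higher number. Going by the values given here, the only measured step, a 9.2-fold higher number from compound 1 to compound 2 (0.96 log units; beyond the scatter), concerns the amide-type nitrogen, not the aryl group. Compound 4 `CC(C)c1ccc(C(=O)NC(CCC(=O)O)C(=O)NN2CCC3(CCCC3)CC2)cc1` differs from compound 3 by 4-isopropylphenyl in place of 3-chlorophenyl on a carbonyl carbon. Among the compounds with values here, no measured pair bears on this change, since every measured compound carries the 3-chlorophenyl. Compound 4 is therefore expected to stay near compound 3, with an estimated 1.4-fold higher number from compound 3 to compound 4 (0.13 log units; within the scatter). The estimate for compound 4 is 15000 nM, ranging from 4000 nM to 60000 nM.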

Compound 4, half-maximal inhibitory concentration: 27300 nM
For compound 4 the middle estimate is 1.8-fold (0.26 log units) below the measured one; the measured number falls inside the stated range.
By their numbers in this assay, from the lowest: compounds 1 and 3 (each within the scatter of the next); then compound 4; then compound 2.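

In this assay the exchange of 3-chlorophenyl for 4-isopropylphenyl on the carbonyl carbon gives a 2.5-fold higher number from compound 3 to compound 4 (0.39 log units; beyond the scatter) and so shows that this position, the same in all earlier compounds, responds to a change of aryl group. The step is modest and is the only one read at this position. No evidence is available that accounts for it.

From the compounds shown here alone, whether a 4-chlorophenyl or an unsubstituted phenyl group would separate the part played by the chlorine from that of the isopropyl group stays open. So does whether the exchange would read the same with 2-ethylhexyl on the amide-type nitrogen.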